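This account rests on a few compounds, and the source may have more. Where it says the series, first, only, none or still open, it means among the compounds named here.

Compound 1 `CS(=O)(=O)c1ccc(-c2cnc3[nH]cc(-c4nnc(-c5ccc(F)cc5)o4)c(=O)c3c2)cc1`: 9.45%
Compound 2 `O=c1c(-c2nnc(-c3ccc(Cl)cc3)o2)c[nH]c2ncc(-c3ccccc3)cc12`: 5.1%

Both measured compounds were tested in a functional assay on HepG2 cells (Homo sapiens) for inhibition, read by MTT assay, with a stated time of 24 h, tested at 5 uM; on this read-out higher numbers stand for more inhibition of growth at the one concentration tested and lower numbers for less inhibition of growth. Compound 1 gives 9.45%, and compound 2 gives 5.1%. The two values lie within the usual scatter of each other, so no order between them can be read, and both show little inhibition of growth at the concentration tested. Compound 3 `Cc1cccc(-c2nnc(-c3c[nH]c4ncc(-c5ccc(S(C)(=O)=O)cc5)cc4c3=O)o2)c1` differs from compound 1 in one place: 3-methylphenyl in place of 4-fluorophenyl on an aromatic carbon. Going by the values given here, no pair of measured compounds differing in a single place is available, so the size of such a step has not been seen directly. Because compound 1 gives 9.45% and compound 2 gives 5.1%, both low, the change in compound 3 is expected to bring no step beyond the scatter in this assay. The estimated step is a number 1.5 percentage points lower from compound 1 to compound 3 (within the scatter). Compound 3 is estimated at 8%, within a range from -5% to 22%.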

Compound 3, percent growth inhibition at one concentration: 13.2%
For compound 3 the middle estimate is 5.2 percentage points below the measured one, and the stated range covers the measured number.
By their numbers in this assay, from the lowest: compounds 2, 1 and 3 (each within the scatter of the next).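

In this assay, the exchange of 4-fluorophenyl for 3-methylphenyl on the aromatic carbon of the five-membered ring gives the first step seen directly at this position: a number 3.8 percentage points higher from compound 1 to compound 3 (within the scatter). A fluorine on the phenyl ring and a methyl at another place on it thus give values that cannot be told apart, and compound 3, at 13.2%, like compound 1, shows little inhibition of growth at the one concentration tested. Nothing at hand offers an explanation for this result.

Going by these compounds, both groups are phenyl rings with 0 hydrogen-bond donors and 0 hydrogen-bond acceptors, so an amine or a carboxylic acid on that phenyl ring remains open. On these data alone, whether any group at this position, such as a longer chain, gives a step beyond the scatter also remains open.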